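This account rests on a few compounds, and the source may have more. Where it says the series, first, only, none or still open, it means among the compounds named here.

Working notes on the oxazole ketone series in an assay on HEK-293T cells for inhibition of diacylglycerol lipase-alpha (Homo sapiens), read by colorimetric assay; on this read-out higher numbers stand for weaker inhibition and lower numbers for stronger inhibition.

Compound 1 `CC(=O)c1cnc(C(=O)CCCCCCc2ccccc2)o1` carries an acetyl group on the core. In this assay compound 1 gives only a limit of > 10000 nM, not a number. Compound 2 `O=C(CCCCCCc1ccccc1)c1ncc(-c2ccccc2F)o1` carries a 2-fluorophenyl group in the same position. In this assay compound 2 also gives only a limit of > 10000 nM. The step that the two limits leave unreadable from compound 1 to compound 2 is therefore unreadable; both values sit at the limit described in the limit of > 10000 nM in this assay, at which 2 of the 2 values shown sit, so compound 2 stands at the weak end of what the assay can report, with no number attached.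

Compound 3 `COc1ccc(-c2cnc(C(=O)CCCCCCc3ccccc3)o2)nc1` differs from compound 2 by 5-methoxypyridin-2-yl in place of 2-fluorophenyl on an aromatic carbon. Within the data shown here, no measured step bears on this change, since the only measured step is itself unreadable. With both measured compounds at the limit, compound 3 is expected to sit near the limit as well, and the step of a number no higher from compound 2 to compound 3 (the limit leaves the size open) is expected to be essentially none beyond the scatter. The estimate for compound 3 is 10000 nM, within a range from 2500 nM to 40000 nM, most likely reported again as a limit.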

Compound 3, half-maximal inhibitory concentration: > 10000 nM
Compound 3: a limit, no number; the forecaster's own chance of this, stated with the estimate: 70%; the middle value lies on the limit itself.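

In this assay, among these compounds, compound 3 gives only a limit, > 10000 nM, so its steps from compound 1 and compound 2 cannot be read and no new step follows. The compounds shown leave open whether any group in this position on the shared core gives a readable number: the limit of > 10000 nM in this assay, at which 3 of the 3 values shown sit.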